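Thiophenyl to phenyl on the shared core: expectation

The compounds below may be only part of what the source reports. "The series", "measured", "known", "first", "only" and "open" are said of these compounds alone.

Two measured compounds frame the question. Compound 1 `COc1cccc(-c2nn3cc(-c4cccc(N)c4)nc3s2)c1`, which carries a different arrangement of the fused core, gives 29000 nM in a functional assay on FM3A cells (Mus musculus) for inhibition, read by cell counting, with a stated time of 2 days; on this read-out lower numbers stand for stronger inhibition and higher numbers for weaker inhibition. Compound 2 `Nc1cccc(-c2cn3nc(-c4cccs4)sc3n2)c1` is recorded in this assay only as a limit, > 250000 nM, not as a number. For the measured compounds named here, compound 2 therefore stands at the weak end of what this assay reports, as noted under (the limit of > 250000 nM in this assay, at which 1 of the 2 values shown sits), and no step between compound 1 and compound 2 is computed here, since they differ in more than one place.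

Compound 3 `Nc1cccc(-c2cn3nc(-c4ccccc4)sc3n2)c1` is not yet measured in this assay. It differs from compound 2 by phenyl in place of thiophen-2-yl on an aromatic carbon.

Going by the values given here, no measured step of this kind exists, so the expectation rests on compound 2 alone. Its value > 250000 nM is a limit, so the step from it to compound 3 can be stated only loosely: the expected step of a number no higher from compound 2 to compound 3 (the limit leaves the size open) is essentially none beyond the scatter, with a substantial chance that compound 3 is again reported only as a limit. On that basis compound 3 is estimated at 250000 nM in this assay, within a range of 60000 nM to 1000000 nM.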

Compound 3, half-maximal inhibitory concentration: 14000 nM
For compound 3 the middle estimate is 18-fold (1.25 log units) above the measured one; the whole stated range lies above it.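

At this position, on an aromatic carbon next to the ring nitrogen and next to the ring sulfur, the choice of aromatic ring has a large effect in this assay: phenyl in place of thiophen-2-yl gives an at least 17-fold lower number from compound 2 to compound 3 (1.25 log units; beyond the scatter). Compound 2 is recorded only as a limit, so the size of this step stays open at its upper end: the limit of > 250000 nM in this assay, at which 1 of the 3 values shown sits.

With compound 3 in hand, the methoxy group on compound 1 can also be read on its own, and hydrogen in place of methoxy on an aromatic carbon gives a 2.1-fold lower number from compound 1 to compound 3 (0.32 log units; beyond the scatter), a modest step beside the large one from thiophen-2-yl to phenyl.

The compounds shown carry only phenyl, 3-methoxyphenyl and thiophen-2-yl at this position, so the effect of a pyridine ring, a cyclohexyl ring or a simple methyl group there remains open, as does whether substituents on the phenyl of compound 3 other than methoxy behave alike. All three compounds also keep the same aminophenyl group on the shared core, which leaves open what a hydroxyl group, an acetamide or a hydrogen in place of that amine would do.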